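The compounds below may be only part of what the source reports. "The series", "measured", "known", "first", "only" and "open" are said of these compounds alone.

Compound 1, `COc1ccc(-n2nncc2CN2C(=O)C3(C(C#N)=C(N)Oc4c3c3nc5ccccc5nc3c3ccccc43)c3ccccc32)cc1`: in a functional assay on A549 cells (Homo sapiens) for antiproliferative activity, read by MTT assay, with a stated time of 48 h (a lower number here means a stronger inhibitor, a higher number a weaker inhibitor), compound 1 gives only a limit of the assay, > 50000 nM.
Compound 2, `N#CC1=C(N)Oc2c(c3nc4ccccc4nc3c3ccccc23)C12C(=O)N(Cc1cnnn1-c1cccc(S(N)(=O)=O)c1)c1ccccc12`: in this assay compound 2 gives 44200 nM.
Compound 3, `Cc1ccc(C)c(-n2nncc2CN2C(=O)C3(C(C#N)=C(N)Oc4c3c3nc5ccccc5nc3c3ccccc43)c3ccccc32)c1`: in this assay compound 3 gives only a limit of the assay, > 50000 nM.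

Compound 1 thus stands only at a limit of the assay, a position it shares with compound 3, as the limit of > 50000 nM in this assay, at which 2 of the 3 values shown sit, records. The unmeasured compound 4, `Cc1cc(C)cc(-n2nncc2CN2C(=O)C3(C(C#N)=C(N)Oc4c3c3nc5ccccc5nc3c3ccccc43)c3ccccc32)c1`, differs from compound 1 by 3,5-dimethylphenyl in place of 4-methoxyphenyl on an aromatic nitrogen. Among the compounds with values here, two measured steps bear on this change: an at least 1.1-fold lower number from compound 1 to compound 2 (0.05 log units; that floor lies within the scatter) and a step that the two limits leave unreadable from compound 1 to compound 3. The first is small and the second is left unread by the two limits, so nothing here points to a move beyond the scatter. Compound 4 is therefore expected to show a step that the limit leaves unreadable from compound 1 to compound 4. For compound 4 the estimated value is 60000 nM, with a range from 30000 nM to 150000 nM, and the assay is expected most likely to report only a limit again.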

Compound 4, half-maximal inhibitory concentration: > 50000 nM
Compound 4 ended at the assay's limit; the forecaster's own chance of this, stated with the estimate: 75%; the middle value does not contradict the limit.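

A third aryl group on this aromatic nitrogen, the 3,5-dimethylphenyl of compound 4, gives the same limit as the 4-methoxyphenyl of compound 1 and the 2,5-dimethylphenyl of compound 3 in this assay: the limit of > 50000 nM in this assay, at which 3 of the 4 values shown sit.
The steps among these three compounds cannot be read. Within the data shown here, the one readable step is an at least 1.1-fold higher number from compound 2 to compound 4 (0.05 log units; that floor lies within the scatter), so the change shows no move beyond the scatter.

Going by these compounds, how far compound 1, compound 3 and compound 4 lie past the limit stays open. So does whether an amine or a carboxylic acid on this phenyl ring would bring a value clearly within the assay's range.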